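Chloro on the amino-bearing ring of compound 1

The source may report more compounds than this note shows. Statements on the series, on what has been measured and on what is new or still open speak of the compounds shown alone.

Among the measured compounds shown here, compound 1 `Nc1ccc2cccc(NC(=O)Nc3ccc(Cl)c(C(F)(F)F)c3)c2c1` stands as the stronger of the two measured members in an in vitro functional assay on cells for antagonist activity at transient receptor potential cation channel subfamily V member 1 (Homo sapiens), read by reporter gene assay and calcium flux (on this read-out higher numbers stand for weaker inhibition and lower numbers for stronger inhibition), where compound 1 gives 34 nM. Compound 2 `O=C(Nc1ccc(Cl)c(C(F)(F)F)c1)Nc1cccc2ccc(NCc3ccccc3)cc12` carries a benzyl on the ring amine instead of hydrogen; in this assay compound 2 gives 140 nM, and the step of a 4.1-fold higher number from compound 1 to compound 2 (0.61 log units; beyond the scatter) is modest but beyond the scatter.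

Compound 3 `Nc1cc2c(NC(=O)Nc3ccc(Cl)c(C(F)(F)F)c3)cccc2cc1Cl` differs from compound 1 by chloro in place of hydrogen on an aromatic carbon. For the measured compounds named here, the only measured step, a 4.1-fold higher number from compound 1 to compound 2 (0.61 log units; beyond the scatter), concerns a substituent on the amine nitrogen rather than on a ring carbon, so it does not bear directly on this change, and no measured pair shows what a chloro at this place does to the number. The urea and the chloro-trifluoromethylphenyl part are untouched. With nothing to rest a direction on, no step beyond the scatter is expected, and the estimated step is a 1.2-fold higher number from compound 1 to compound 3 (0.07 log units; within the scatter). For compound 3 in this assay the estimate is 40 nM, with a range from 12 nM to 130 nM.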

Compound 3, half-maximal inhibitory concentration: > 1000 nM
Compound 3 gave a limit, no number; the forecaster's own chance of this, stated with the estimate: 3%; middle value at least 25-fold (1.39 log units) from the limit.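

The aromatic carbon ortho to an amino group is a sensitive place on the shared core: chloro in place of hydrogen there produces an at least 29-fold higher number from compound 1 to compound 3 (1.46 log units; beyond the scatter) in this assay. Among the compounds shown here, until now the only change read on this part of the core sat on the amine nitrogen, with a benzyl giving a 4.1-fold higher number from compound 1 to compound 2 (0.61 log units; beyond the scatter), so a single chlorine on the ring carbon weighs more here than a whole benzyl on the nitrogen. The reading for compound 3 is a limit of the assay and not a number, so the step has a lower bound but no fixed size: the limit of > 1000 nM in this assay, at which 1 of the 3 values shown sits.

Whether this loss belongs to chloro alone or to any group on this carbon stays open, since a fluoro or a methyl at this place is not among the compounds shown. Also open, going by these compounds, is how a chloro on the other carbons of this ring would read, and whether a methoxy at this place would keep the inhibition seen with hydrogen.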